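The compounds below may be only part of what the source reports. "The series", "measured", "known", "first", "only" and "open" are said of these compounds alone.

Three compounds have numbers in a functional assay on HT-29 cells (Homo sapiens) for inhibition, read by MTT assay, with a stated time of 72 h; on this read-out higher numbers stand for weaker inhibition of growth and lower numbers for stronger inhibition of growth. Compound 1 `N#C/C(=C\c1c(F)c(F)c(F)c(F)c1F)C(=O)c1c[nH]c2ccccc12` gives 18000 nM. Compound 2 `N#C/C(=C\c1ccc[nH]1)C(=O)NCc1ccc(Cl)c(Cl)c1` gives 85000 nM in this assay. Compound 3 `COc1ccc(CNC(=O)/C(C#N)=C/c2ccc(C)o2)cc1` gives 92000 nM in this assay, the highest of the three numbers: the gap to compound 2 lies within the scatter, while the gap to compound 1 lies beyond it, so compound 3 and compound 2 stand together at the weak end of the set and compound 1 sits apart with the stronger inhibition of growth.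

Compound 4 `COc1ccc(CNC(=O)/C(C#N)=C/c2ccc(-c3ccccc3)o2)cc1` has not yet been measured. From compound 3 it differs in one place: phenyl in place of methyl on an aromatic carbon. Among the measured compounds shown here, no pair of measured compounds differs by this exchange, so no step of the same kind is at hand; compounds 1, 2 and 3 differ from one another in several places at once and say nothing about this change taken alone. Any expectation for compound 4 therefore rests on the number of compound 3 and on the general spread seen across the three measured compounds. The expected step is a 2.3-fold lower number from compound 3 to compound 4 (0.36 log units; beyond the scatter), a modest move toward stronger inhibition that need not pass beyond the scatter. Compound 4 is estimated at 40000 nM, with a range from 10000 nM to 150000 nM.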

Compound 4, concentration for 50% growth inhibition: 56000 nM
For compound 4 the middle estimate is 1.4-fold (0.15 log units) below the measured one; the range from low to high includes it.
By their numbers in this assay, from the lowest: compound 1; then compounds 4, 2 and 3 (each within the scatter of the next).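

In this assay, phenyl in place of methyl on the aromatic carbon next to the ring oxygen gives a 1.6-fold lower number from compound 3 to compound 4 (0.22 log units; within the scatter), the only direct reading of this position in the compounds shown. Compound 3 and compound 4 therefore cannot be told apart on this read-out, even though the entering group brings a whole six-membered aromatic ring of carbon to a place that held a single methyl carbon. So this one exchange, large as it is in heavy atoms, gives no step beyond the scatter, and nothing measured here offers an explanation for that.

From the compounds shown here alone, it remains open whether a different group at this place, such as an amine, a carboxylic acid or a longer alkyl chain, or a substituent such as chlorine on the entering phenyl, would give a step beyond the scatter. Going by these compounds, it also remains open whether the exchange of methyl for phenyl would read the same way in a compound lacking the methoxy group that compound 3 and compound 4 share.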